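A few compounds are considered here, and "the series" means these few. Any claim that something is new, unique, unknown or untested is made for them only; others in the source may bear on it.

In a functional assay on HeLa cells (Homo sapiens) for antiproliferative activity, read by MTT assay, with a stated time of 72 h (on this read-out lower numbers stand for stronger inhibition and higher numbers for weaker inhibition), compound 1 `COc1ccc(-c2cnc3scc(C(=O)NNC(C)=O)n23)cc1` gives 17900 nM and compound 2 `CCC(=O)NNC(=O)c1csc2ncc(-c3ccc(OC)cc3)n12` gives 56200 nM, the higher of the two numbers. Compound 3 `CCCC(=O)NNC(=O)c1csc2ncc(-c3ccc(OC)cc3)n12` differs from compound 2 by methyl in place of hydrogen on a saturated chain carbon, two bonds along the chain from a carbonyl carbon, with methyl in place of hydrogen on a saturated chain carbon, two bonds along the chain from a carbonyl carbon. Going by the values given here, the only measured step that bears on this is the methyl for hydrogen on a saturated chain carbon bound to a carbonyl carbon, a 3.1-fold higher number from compound 1 to compound 2 (0.50 log units; beyond the scatter), which is modest but beyond the scatter. On this single precedent, a smaller rise in the same direction is expected in this assay, an estimated 1.4-fold higher number from compound 2 to compound 3 (0.15 log units; within the scatter). Compound 3 is expected at 80000 nM, with an estimated range of 32000 nM to 180000 nM.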

Compound 3, half-maximal inhibitory concentration: 43300 nM
For compound 3 the middle estimate is 1.8-fold (0.27 log units) above the measured one, and the stated range covers the measured number.
By their numbers in this assay, from the lowest: compound 1; then compounds 3 and 2 (each within the scatter of the next).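

In this assay, lengthening the chain from ethyl to propyl does not carry the earlier rise any further, since a 1.3-fold lower number from compound 2 to compound 3 (0.11 log units; within the scatter) is a step that cannot be told apart from repeat measurement. Set against the methyl end of this series, the propyl chain of compound 3 still stands clear, with a 2.4-fold higher number from compound 1 to compound 3 (0.38 log units; beyond the scatter) as the step, so among these three compounds the change beyond the scatter remains the one on the saturated chain carbon bound to a carbonyl carbon.

On these data alone, whether a longer chain, a branched chain or a terminal amine or carboxylic acid would shift the number stays open. No measured evidence here accounts for these steps.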